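The compounds below may be only part of what the source reports. "The series", "measured", "known", "first", "only" and "open" are said of these compounds alone.

Measured compounds in a functional assay on OVCAR-3 cells (Homo sapiens) for cytotoxicity, read by sulforhodamine B assay, with a stated time of 48 h, tested at 100 uM; on this read-out lower numbers stand for a stronger effect and higher numbers for a weaker effect at the one concentration tested:
compound 1, `COc1cc(-c2cc(/C=C/C(=O)c3ccc(N)cc3)[nH]n2)cc(OC)c1OC`, gives -93%
compound 2, `COc1ccc(C(=O)/C=C/c2cc(-c3cc(OC)c(OC)c(OC)c3)n[nH]2)cc1OC`, gives -84%
compound 3, `COc1ccc(C(=O)/C=C/c2cc(-c3cc(OC)c(OC)c(OC)c3)n[nH]2)cc1`, gives -69%

Compound 1 and compound 2 give numbers within the scatter of one another, the step being a number 9 percentage points higher from compound 1 to compound 2 (within the scatter). Compound 3 stands apart from both: a number 24 percentage points higher from compound 1 to compound 3 (beyond the scatter) and a number 15 percentage points higher from compound 2 to compound 3 (beyond the scatter). The change that separates compound 2 from compound 3 is hydrogen in place of methoxy on an aromatic carbon, and it made a step of a number 15 percentage points higher from compound 2 to compound 3 (beyond the scatter) in this assay.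

The unmeasured compound 4, `COc1ccc(-c2cc(/C=C/C(=O)c3ccc(N)cc3)[nH]n2)cc1OC`, is derived from compound 1 by the same kind of change, (hydrogen in place of methoxy on an aromatic carbon). The two cores on which the change is made differ: 4-aminophenyl in place of 3,4-dimethoxyphenyl on a carbonyl carbon. The surroundings of the place are not the same word for word either; in compound 1 the carbon that loses the methoxy is also meta to a methoxy group, which is not said of the place in compound 2, so the change counts as the same kind of change, not the same change.

For compound 4 a step of a number 15 percentage points higher from compound 1 to compound 4 (beyond the scatter) is expected from compound 1, and this expectation rests on the step of a number 15 percentage points higher from compound 2 to compound 3 (beyond the scatter) seen on the other core. Compound 4 is therefore estimated to give -78% in this assay. The estimate for compound 4 is expected to fall between -95% and -55%.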

Compound 4, a percentage reported as activity, at one concentration (the size of the read-out at that concentration, not a potency): -99%
The estimate for compound 4 lay 21 percentage points above the measured number; the measured number lies below the stated range.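

In this assay, putting hydrogen in place of methoxy on the core of compound 1 gave a step of a number 6 percentage points lower from compound 1 to compound 4 (within the scatter), so the weakening of the effect seen with this kind of change on the core of compound 2 did not reappear. The change therefore cannot be carried from one core to the other in this series as a fixed increment, and the two steps do not agree: the same change on two cores in this assay, a number 15 percentage points higher (beyond the scatter) from compound 2 to compound 3 and a number 6 percentage points lower (within the scatter) from compound 1 to compound 4, 21 percentage points apart, beyond the scatter of two such steps This shows only that the outcome depends on something that differs between the two pairs, not what that something is, since the cores differ in the aminophenyl and dimethoxyphenyl groups and the surroundings of the place also differ, and a single pair on each core cannot separate these or say how the change would behave on a third core.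

The compounds shown leave open how other groups would behave at the place of the change, for example a hydroxyl group, a chlorine atom or a longer alkoxy chain in place of the methoxy group. They also leave open whether a carboxylic acid or an amide in place of the amino group of compound 4 would keep the effect, and how the compounds would compare at any concentration other than the one tested.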